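Moving the fluorine on the ring-nitrogen aryl group

The source may hold more compounds than are shown below. What is called first, only, known or untested is meant among the compounds shown, and "the series" means these compounds.

Three measured compounds share one core and differ only in the aryl group on the amide-type nitrogen in a ring. Compound 1 `O=C(NCCCCc1ccccc1)c1cccc(C2SCC(=O)N2c2ccc(-c3ccccc3)cc2)c1` carries 4-phenylphenyl there. In a functional assay on HOS-TE85 cells (Homo sapiens) for inhibition, read by CCK-8 assay, with a stated time of 72 h (on this read-out lower numbers stand for stronger inhibition and higher numbers for weaker inhibition), compound 1 gives only a limit, > 1000 nM, which is the limit of > 1000 nM in this assay, at which 1 of the 3 values shown sits. Compound 2 `C#Cc1cccc(N2C(=O)CSC2c2cccc(C(=O)NCCCCc3ccccc3)c2)c1` carries 3-ethynylphenyl, and in this assay compound 2 gives 149 nM. Compound 3 `COc1cc(F)ccc1N1C(=O)CSC1c1cccc(C(=O)NCCCCc2ccccc2)c1` carries 4-fluoro-2-methoxyphenyl, and in this assay compound 3 gives 71.1 nM, the lowest of the two numbers; compound 2 is nearest, the step being a 2.1-fold lower number from compound 2 to compound 3 (0.32 log units; beyond the scatter). Relative to the limit of compound 1 the steps are an at least 6.7-fold lower number from compound 1 to compound 2 (0.82 log units; beyond the scatter) and an at least 14-fold lower number from compound 1 to compound 3 (1.14 log units; beyond the scatter).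

Compound 4 `COc1c(F)cccc1N1C(=O)CSC1c1cccc(C(=O)NCCCCc2ccccc2)c1` differs from compound 3 by 3-fluoro-2-methoxyphenyl in place of 4-fluoro-2-methoxyphenyl on an amide-type nitrogen in a ring. For the measured compounds named here, none of the measured steps bears directly on this: each swaps the whole aryl group, whereas here only the place of the fluorine on the 2-methoxyphenyl changes and the atoms stay the same. The measured steps therefore set the level of compound 3 as the starting point but give no size for this shift. No step beyond the scatter is expected, which gives a 1.3-fold higher number from compound 3 to compound 4 (0.10 log units; within the scatter). Compound 4 is estimated at 90 nM in this assay, with a range from 35 nM to 250 nM.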

Compound 4, half-maximal inhibitory concentration: 26.2 nM
Compound 4: the middle estimate sits 3.4-fold (0.54 log units) above what was measured; the measured number lies below the stated range.
By their numbers in this assay, from the lowest: compound 4; then compound 3; then compound 2. At a limit, above all of these: compound 1.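

In this assay the place of the fluorine on the 2-methoxyphenyl group counts by itself: with the same atoms and the same counts on both sides, the move from 4-fluoro-2-methoxyphenyl to 3-fluoro-2-methoxyphenyl gives a 2.7-fold lower number from compound 3 to compound 4 (0.43 log units; beyond the scatter), a size that the earlier swaps of the whole aryl group could not give. The same change of group leaves 3-ethynylphenyl further behind, with a 5.7-fold lower number from compound 2 to compound 4 (0.75 log units; beyond the scatter), and compound 4 now has the lowest number of the series, with steps beyond the scatter to compound 2 and compound 3. Compound 1 stands only as a limit, so an at least 38-fold lower number from compound 1 to compound 4 (1.58 log units; beyond the scatter) is a bound and not a measured size: the limit of > 1000 nM in this assay, at which 1 of the 4 values shown sits.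

Going by these compounds, whether the fluorine is needed at all stays open, and the plain 2-methoxyphenyl group, 3-chloro-2-methoxyphenyl or 3-fluoro-2-ethoxyphenyl would test how far this gain depends on that atom and on the methoxy group. On these data alone, the phenylbutyl chain on the amide is the same in all four compounds, so it also stays open whether the gain carries over to a shorter chain or to a chain ending in an amine.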